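A few compounds are considered here, and "the series" means these few. Any claim that something is new, unique, unknown or untested is made for them only; others in the source may bear on it.

Three compounds sharing one core, each carrying a halogen-substituted phenyl group on a sulfur-linked side chain, have been tested in an assay on isolated protein for inhibition of Amine oxidase [flavin-containing] B (Homo sapiens); on this read-out higher numbers stand for weaker inhibition and lower numbers for stronger inhibition. Compound 1 `C#CCNC1CCc2c(SCCc3ccc(Br)cc3)cccc21` gives 85300 nM. Compound 2 `C#CCNC1CCc2c(SCCc3ccc(Cl)cc3)cccc21` gives 10800 nM. Compound 3 `C#CCNC1CCc2c(SCc3cccc(Cl)c3)cccc21` gives 23300 nM.

Compound 1 and compound 2 differ in a single change, (bromo in place of chloro on an aromatic carbon), and that step, a 7.9-fold higher number from compound 2 to compound 1 (0.90 log units; beyond the scatter), is a move toward weaker inhibition. Compound 3 differs from compound 2 in more than one place; how the two cores differ is not broken down here, so the gap between them, beyond the usual scatter, can only be noted as it stands.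

The unmeasured compound 4 `C#CCNC1CCc2c(SCc3cccc(Br)c3)cccc21` is compound 3 with the change (bromo in place of chloro on an aromatic carbon). Among the measured compounds shown here, this is the same kind of change as the one from compound 2 to compound 1, but not the same: in compound 2 the halogen sits para to a large group, whereas in compound 3 it sits meta to a large group, and the side chain linking the ring to the core is not identical between the two pairs. Because the earlier step of a 7.9-fold higher number from compound 2 to compound 1 (0.90 log units; beyond the scatter) was clearly toward weaker inhibition, a step in the same direction is expected for compound 4, though somewhat smaller given that the surroundings of the change are not identical, so compound 4 is estimated to move by a 3.9-fold higher number from compound 3 to compound 4 (0.59 log units; beyond the scatter) in this assay. On that basis compound 4 is expected to give about 90000 nM in this assay, most plausibly between 30000 nM and 250000 nM.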

Compound 4, half-maximal inhibitory concentration: > 100000 nM
Compound 4: no number, only a limit (the forecaster's own chance of this, stated with the estimate: 25%); middle value at least 1.1-fold (0.04 log units) away from the limit.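

In this assay, compound 4 gives > 100000 nM, which is a limit of the assay and not a number. Putting bromo in place of chloro on the aromatic ring gives an at least 4.2-fold higher number from compound 3 to compound 4 (0.63 log units; beyond the scatter), so the change moves toward weaker inhibition in both pairs shown, and its direction carries over from one core to the other: the same change on two cores in this assay, a 7.9-fold higher number (0.90 log units; beyond the scatter) from compound 2 to compound 1 and an at least 4.2-fold higher number (0.63 log units; beyond the scatter) from compound 3 to compound 4; the limit leaves it open whether they differ. What this does not show is how large the effect is on the second core, or whether it is larger or smaller than on the first, since the true value of compound 4 lies somewhere past the end of what the assay reports: the limit of > 100000 nM in this assay, at which 1 of the 4 values shown sits.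

With only two pairs, and with the side chain and the place of the halogen both differing between them, the compounds shown cannot say which of those features, if either, influences the size of the step. They also leave open what a fluoro group or an amine would do in place of the halogen on either core, and whether a longer chain between the sulfur and the ring would keep the same order of chloro and bromo.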